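The source may report more compounds than this note shows. Statements on the series, on what has been measured and on what is new or still open speak of the compounds shown alone.

Three compounds share one core and differ only in the aromatic group attached to it. Compound 3 `COc1ccc(Cc2cc(-c3ccc(C)cc3)nn(CC(=O)Nc3ccc(Br)cc3)c2=O)cc1` carries a 4-methylphenyl group. In a functional assay on HL-60 cells (Homo sapiens), read by calcium flux (on this read-out higher numbers stand for an effect only at larger amounts of compound and lower numbers for an effect already at smaller amounts), compound 3 gives > 50000 nM, which is a limit of the assay and not a number. Compound 1 `COc1ccc(Cc2cc(-c3cccs3)nn(CC(=O)Nc3ccc(Br)cc3)c2=O)cc1` carries a thiophen-2-yl group in the same place. In this assay compound 1 gives > 50000 nM, again a limit. Compound 2 `COc1ccc(Cc2cc(-c3ccc(Cl)cc3)nn(CC(=O)Nc3ccc(Br)cc3)c2=O)cc1` carries a 4-chlorophenyl group. Compound 2 gives > 50000 nM in this assay, also a limit. Because all three values sit at the limit of > 50000 nM in this assay, at which 3 of the 3 values shown sit, none of the steps between them can be read: the step that the two limits leave unreadable from compound 1 to compound 2, the step that the two limits leave unreadable from compound 1 to compound 3 and the step that the two limits leave unreadable from compound 2 to compound 3 all stay without a size. Compound 3 thus stands at the limit together with the other two, with no ordering among them.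

Compound 4 `COc1ccc(Cc2cc(-c3ccc(F)cc3)nn(CC(=O)Nc3ccc(Br)cc3)c2=O)cc1` is the next member. The change from compound 3 to compound 4 is fluoro in place of methyl on an aromatic carbon. The measured steps that bear on it are the three unreadable ones among compounds 1, 2 and 3, which exchange groups in the same place without any compound leaving the limit. The step that the limit leaves unreadable from compound 3 to compound 4 is therefore expected to show no effect beyond the scatter, in either direction. Compound 4 is estimated to give 80000 nM in this assay, within a range from 20000 nM to 300000 nM, most likely again as a limit rather than a number.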

Compound 4, half-maximal effective concentration: > 50000 nM
Compound 4 ended at the assay's limit; the forecaster's own chance of this, stated with the estimate: 85%; the middle value lies beyond the limit too.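

In this assay compound 4 gives > 50000 nM, which is a limit of the assay and not a number. The steps from compound 1, compound 2 and compound 3 to compound 4 therefore cannot be read, as every value sits at the same limit: the limit of > 50000 nM in this assay, at which 4 of the 4 values shown sit.

The compounds shown leave open whether any group in this place gives a measurable effect in this assay, and how these four groups would rank.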